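The compounds below may be only part of what the source reports. "The series", "measured", "known", "first", "only" and "open" are said of these compounds alone.

In a physicochemical assay for solubility, measured as kinetic solubility, with a stated time of 24 h, at pH 7.4 (a lower number here means a less soluble compound, a higher number a more soluble compound), the measured compounds read:
- compound 1 `O=C(NCc1ccc(S(=O)(=O)C2CCOCC2)cc1)c1cc2ccncc2o1` gives 111000 nM
- compound 2 `O=C(NCc1ccc(S(=O)(=O)C2CCOCC2)cc1)c1cc2cnccc2[nH]1` gives 15000 nM
- compound 3 `CC(C)N1CCC([S+]([O-])c2ccc(CNC(=O)c3cc4ccncc4o3)cc2)CC1` gives 153000 nM; 167000 nM; 175000 nM (3 entries) over repeated entries

Compound 1 is the higher of the two compounds with a single number. The repeated entries of compound 3 (the several entries of compound 3 in this assay, 153000 nM; 167000 nM; 175000 nM (3 entries)) lie within the usual scatter of compound 1 and give no single number.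

Compound 4 `CC(C)n1cc(S(=O)(=O)c2ccc(CNC(=O)c3cc4ccncc4o3)cc2)cn1` has not yet been measured. It carries 1-isopropyl-1H-pyrazol-4-yl in place of oxan-4-yl on a sulfonyl sulfur and keeps the rest of compound 1 unchanged.

Among the measured compounds shown here, the only measured step at a single place is a 7.4-fold lower number from compound 1 to compound 2 (0.87 log units; beyond the scatter) and it lies on a carbonyl carbon. It therefore says nothing direct about the sulfonyl sulfur and serves only as a gauge of how far one change has moved the number in this short series. For the measured compounds named here, no step at the sulfonyl sulfur has been measured, so the range stays wide.

In this assay a lower number is expected, with a step smaller than the one on the carbonyl carbon. The estimated step is a 2.5-fold lower number from compound 1 to compound 4 (0.39 log units; beyond the scatter) and it remains an expectation. For compound 4 the expected value is 45000 nM within an estimated range of 12000 nM to 130000 nM until the measurement is in.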

Compound 4, solubility: 12000 nM
Estimate against measurement, compound 4: 3.8-fold (0.57 log units) above, and the stated range covers the measured number.
By their numbers in this assay, from the lowest: compounds 4 and 2 (each within the scatter of the next); then compound 1.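

The first measured step on a sulfonyl sulfur, in this assay, is a 9.3-fold lower number from compound 1 to compound 4 (0.97 log units; beyond the scatter); the earlier step of a 7.4-fold lower number from compound 1 to compound 2 (0.87 log units; beyond the scatter) lay on a carbonyl carbon, so this position has now been shown to move the number beyond the scatter as well. The step arises between two groups that both carry no hydrogen-bond donors and no net charge: 1-isopropyl-1H-pyrazol-4-yl, a five-membered aromatic ring, enters where oxan-4-yl, a six-membered non-aromatic ring, leaves. Ring size, aromatic character and heavy-atom count all change together in this single swap, and nothing measured in this series gives a cause for the step.

Still open, from the compounds shown here alone, is whether the lower number follows the pyrazole ring itself or its isopropyl group, a question that a plain 1-methyl-1H-pyrazol-4-yl on the sulfonyl sulfur would help to separate. Also open, going by these compounds, is how this position responds to a group of another kind on the same sulfur, such as a chain ending in a tertiary amine or a carboxylic acid.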